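The source may report more compounds than this note shows. Statements on the series, on what has been measured and on what is new or still open speak of the compounds shown alone.

Compound 1, `COc1ccccc1NC(=O)Nc1cccc(CNc2ncnc3ccccc23)c1`, was tested in a functional assay on HepG2 cells (Homo sapiens) for antiproliferative activity, read by MTT assay (on this read-out lower numbers stand for stronger inhibition and higher numbers for weaker inhibition), where compound 1 gives 17500 nM. Among the three compounds measured so far, this is the only one that yields a number; the other two reach only a limit of the assay. Compound 2, `COc1ccc(NC(=O)Nc2cccc(CNc3ncnc4ccccc34)c2)cc1`, carries 4-methoxyphenyl in place of 2-methoxyphenyl, and in this assay compound 2 gives > 50000 nM, which is a limit and not a number. Compound 3, `O=C(Nc1cccc(CNc2ncnc3ccccc23)c1)Nc1ccccc1Cl`, carries chloro in place of methoxy, and in this assay compound 3 gives > 50000 nM, again a limit. The two steps away from compound 1 can thus be read only as lower bounds: an at least 2.8-fold higher number from compound 1 to compound 2 (0.45 log units; beyond the scatter) and an at least 2.8-fold higher number from compound 1 to compound 3 (0.45 log units; beyond the scatter). Between the two limits there is a step that the two limits leave unreadable from compound 2 to compound 3. the limit of > 50000 nM in this assay, at which 2 of the 3 values shown sit, marks the edge of what the assay can report.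

Compound 4, `O=C(Nc1cccc(Cl)c1)Nc1cccc(CNc2ncnc3ccccc23)c1`, has not yet been measured. It differs from compound 1 in one place: 3-chlorophenyl in place of 2-methoxyphenyl on an amide-type nitrogen. Because an at least 2.8-fold higher number from compound 1 to compound 2 (0.45 log units; beyond the scatter) and an at least 2.8-fold higher number from compound 1 to compound 3 (0.45 log units; beyond the scatter) both ended at the limit, a loss of the same kind is expected for compound 4: a 2.9-fold higher number from compound 1 to compound 4 (0.46 log units; beyond the scatter). Compound 4 is therefore estimated at 50000 nM, within a range from 17500 nM to 150000 nM, with a fair chance that the assay once more reports only a limit.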

Compound 4, half-maximal inhibitory concentration: > 50000 nM
Compound 4 gave a limit, no number; the forecaster's own chance of this, stated with the estimate: 65%; the middle value lies on the limit itself.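

In this assay, the change to 3-chlorophenyl on the amide-type nitrogen gives an at least 2.8-fold higher number from compound 1 to compound 4 (0.45 log units; beyond the scatter), so a third group in this place fails to keep a readable number. Chlorine now appears in two forms, 2-chlorophenyl in compound 3 and 3-chlorophenyl in compound 4, and neither form returns a number, although the steps among compound 2, compound 3 and compound 4 cannot be read, since each of those values is a limit. Among the four compounds shown, only the 2-methoxyphenyl group of compound 1 gives a number, and none goes against this, but the comparison is bounded by one shared edge of the measurement: the limit of > 50000 nM in this assay, at which 3 of the 4 values shown sit.

The compounds shown leave open how far compound 2, compound 3 and compound 4 differ from one another, and whether the methoxy group itself or simply its place in compound 1 matters. A hydroxyl or an ethoxy group in place of that methoxy, on the same amide-type nitrogen substituent, would speak to this question, and so would a longer ether chain.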